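A few compounds are considered here, and "the series" means these few. Any claim that something is new, unique, unknown or untested is made for them only; others in the source may bear on it.

Working notes on the series. In a functional assay on HEK293 cells for positive allosteric modulation of metabotropic glutamate receptor 5 (Homo sapiens), read by FLIPR and calcium flux (on this read-out lower numbers stand for an effect already at smaller amounts and higher numbers for an effect only at larger amounts of compound), compound 1 `O=C(COCc1ccccc1)N1CCN(c2ccc(F)cc2Cl)CC1` gives 270 nM. Within the data shown here, compound 2 `O=C(COCc1cccnc1)N1CCN(c2ccc(Cl)cc2Cl)CC1` in this assay gives 1090 nM, the higher of the two numbers so far, and these two compounds differ in more than one place, so the pair shows only what its values show. Compound 3 `O=C(CCCc1ccncc1)N1CCN(c2ccc(Cl)cc2Cl)CC1` carries 2-(pyridin-4-yl)ethyl in place of (pyridin-3-yl)methoxy on a saturated chain carbon bound to a carbonyl carbon. Among the measured compounds shown here, no step between measured compounds has been recorded for this change, so the expected step from compound 2 to compound 3 in this assay is a 1.4-fold higher number from compound 2 to compound 3 (0.14 log units; within the scatter), a small change not clearly beyond the scatter. Compound 3 is estimated at 1500 nM, range 400 nM to 6000 nM.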

Compound 3, half-maximal effective concentration: 5300 nM
Compound 3: middle estimate off by 3.5-fold (0.55 log units), on the low side, and the stated range covers the measured number.
By their numbers in this assay, from the lowest: compound 1; then compound 2; then compound 3.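

Among these compounds, at this position on a saturated chain carbon bound to a carbonyl carbon, the change gives a 4.9-fold higher number from compound 2 to compound 3 (0.69 log units; beyond the scatter) in this assay and is the first single-place comparison. The swap of (pyridin-3-yl)methoxy for 2-(pyridin-4-yl)ethyl keeps the count of heavy atoms but replaces the chain oxygen with carbon and also alters the pyridine attachment, so this step covers both changes together. Nothing available explains the step.

As far as these compounds go, whether the chain or the pyridine attachment carries the step remains open. (Pyridin-4-yl)methoxy or 2-(pyridin-3-yl)ethyl at this position would separate the two.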